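Swapping a cyclopropylmethyl for a dichlorobenzyl arm

The source may hold more compounds than are shown below. What is called first, only, known or untested is meant among the compounds shown, and "the series" means these compounds.

Compound 1 `CCN(Cc1c(C(F)(F)F)nc2n(-c3c(C)cc(C)cc3C)c(Cl)cn12)CC1CC1` is the stronger of the two measured compounds: in an assay on cells for displacement of a labelled ligand from corticotropin-releasing factor receptor 1 (Homo sapiens), with a stated time of 100 min (a higher number here means a weaker inhibitor, a lower number a stronger inhibitor), compound 1 gives 9 nM. Among the measured compounds shown here, the only comparison at hand is compound 2 `CCCN(Cc1ccccc1)Cc1c(C(F)(F)F)nc2n(-c3c(C)cc(C)cc3C)c(Cl)cn12`, which carries a benzyl(propyl)amino group in place of the (cyclopropylmethyl)(ethyl)amino group of compound 1; in this assay compound 2 gives 170 nM, a 19-fold higher number from compound 1 to compound 2 (1.28 log units; beyond the scatter).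

Compound 3 `CCN(Cc1ccc(Cl)c(Cl)c1)Cc1c(C(F)(F)F)nc2n(-c3c(C)cc(C)cc3C)c(Cl)cn12` keeps the ethyl arm of compound 1 and changes the other arm: 3,4-dichlorophenyl in place of cyclopropyl on a saturated chain carbon bound to an amine nitrogen. The step from compound 1 to compound 2 is the closest guide, since it also replaces the small saturated ring on that arm with a six-membered aromatic ring, though it alters the ethyl arm at the same time and carries no chlorines. On that basis a weakening beyond the scatter is expected for compound 3, though probably not as large as for compound 2. Compound 3 is therefore estimated at 60 nM in this assay, with a likely range from 15 nM to 250 nM, an expected 6.7-fold higher number from compound 1 to compound 3 (0.82 log units; beyond the scatter).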

Compound 3, inhibition constant: 580 nM
Compound 3: middle estimate off by 9.7-fold (0.99 log units), on the low side; the measured number lies above the stated range.
By their numbers in this assay, from the lowest: compound 1; then compound 2; then compound 3.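

With the ethyl arm held fixed, compound 3 isolates a single change on the saturated chain carbon bound to the amine nitrogen, and in this assay the replacement of cyclopropyl by 3,4-dichlorophenyl gives a 64-fold higher number from compound 1 to compound 3 (1.81 log units; beyond the scatter). The earlier step from compound 1 to compound 2 altered both arms of the amine at once, so it could not show whether this arm alone was enough for a large loss of binding strength; compound 3 shows that it is, since the ethyl arm stays the same as in compound 1. Nothing given here explains why this single change has so large an effect.

The ring swap and the two chlorines arrive together in compound 3, and compound 2 differs from it in both arms, so the share of each remains unresolved. An unsubstituted benzyl group or a cyclohexylmethyl group alongside the ethyl arm would separate the effect of the chlorines from that of the aromatic ring and show whether ring size alone matters at this position.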